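The source may hold more compounds than are shown below. What is called first, only, known or untested is meant among the compounds shown, and "the series" means these compounds.

Compounds measured in an ADME assay on microsomes from liver (Homo sapiens) for metabolic stability; on this read-out lower numbers stand for a shorter-lived compound and higher numbers for a longer-lived compound:

- Compound 1, `O=C(Nc1ccc(-c2cnc3ccccn23)cc1)c1ccc([N+](=O)[O-])o1`: 0.412 h
- Compound 2, `COc1ccn2c(-c3ccc(NC(=O)c4ccc([N+](=O)[O-])o4)c(C)c3)cnc2c1`: 0.665 h

Among the measured compounds shown here, compound 2 holds the higher of the two numbers measured so far in this assay, while compound 1 sits close beneath it, and the gap between them lies within the scatter of the assay, so the two cannot be told apart in this read-out. Both numbers point to short-lived compounds.

Compound 3, `Cc1cc(-c2cnc3ccccn23)ccc1NC(=O)c1ccc([N+](=O)[O-])o1`, has not yet been measured. It differs from compound 2 in a single place: hydrogen in place of methoxy on an aromatic carbon. For the measured compounds named here, with no pair of measured compounds differing in exactly this way, the size of the step cannot be read from the data. Compound 1 and compound 2, which share the same amide and nitrofuran part, already sit within the scatter of each other, which suggests that changes on the core have not so far moved the read-out much. Compound 3 is therefore expected to stay close to compound 2, with the step from compound 2 to compound 3 estimated as a 1.3-fold lower number from compound 2 to compound 3 (0.12 log units; within the scatter), no larger than the scatter and without a clear direction. In this assay compound 3 is expected to give about 0.5 h, with a likely range from 0.25 h to 1 h.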

Compound 3, half-life: 0.612 h
Estimate against measurement, compound 3: 1.2-fold (0.09 log units) below; low and high end bracket the measured number.
By their numbers in this assay, from the lowest: compounds 1, 3 and 2 (each within the scatter of the next).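

In this assay, hydrogen in place of methoxy on an aromatic carbon of the six-membered aromatic ring with 1 nitrogen gives a 1.1-fold lower number from compound 2 to compound 3 (0.04 log units; within the scatter), so at this position, opposite the ring nitrogen, the read-out does not tell methoxy from hydrogen. The second single change now readable, methyl in place of hydrogen on an aromatic carbon, gives a 1.5-fold higher number from compound 1 to compound 3 (0.17 log units; within the scatter), and thus neither of the two changes separates the compounds it links, while all three remain short-lived compounds on this scale. Nothing at hand bears on why these numbers lie so close together.

Among the compounds shown here, open is whether this same position would answer to a group of a different kind, such as an amine, a carboxylic acid or a longer alkoxy chain, since methoxy and hydrogen are the only two groups seen there. From the compounds shown here alone, the amide and the nitrofuran part are the same in all three compounds, so it also remains open how the half-life would respond to a change there, for instance an amine in place of the nitro group.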